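Thiophen-3-yl in Place of Furan-3-yl

The source may report more compounds than this note shows. Statements on the series, on what has been measured and on what is new or still open speak of the compounds shown alone.

Compound 3 `CC1=C(C(=O)CC(C)C)C(c2ccoc2)NC(=O)N1` has the highest of the three numbers in an assay on membranes from HeLa cells for displacement of a labelled ligand from adenosine receptor A3 (Homo sapiens), read by scintillation counting, with a stated time of 180 min, tested at 1 uM (a lower number here means less inhibition, a higher number more inhibition at the concentration tested (going by the name of the read-out)), giving 18%, though both of its neighbours lie within the scatter of it. The nearest is compound 2 `CC1=C(C(=O)C2CC2)C(c2ccoc2)NC(=O)N1`, which in this assay gives 16%; the furthest is compound 1 `CCCOC(=O)C1=C(C)NC(=O)NC1c1ccoc1`, which in this assay gives 11%. The three steps between them, a number 5 percentage points higher from compound 1 to compound 2 (within the scatter), a number 7 percentage points higher from compound 1 to compound 3 (within the scatter) and a number 2 percentage points higher from compound 2 to compound 3 (within the scatter), all stay within the scatter, so changes at the carbonyl carbon have not moved the read-out. Compound 4 `CC1=C(C(=O)CC(C)C)C(c2ccsc2)NC(=O)N1` differs from compound 3 at another place: thiophen-3-yl in place of furan-3-yl on a saturated ring carbon. Among the measured compounds shown here, none of the measured steps touches this position, so no measured step bears directly on the change; the measured steps only show that every variation tried in this set has stayed within the scatter. The expectation for compound 4 in this assay is therefore a step of no change at the digits printed from compound 3 to compound 4 (within the scatter), none beyond the scatter. Compound 4 is estimated to give 18%, with a range from 5% to 32%.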

Compound 4, a percentage reported as inhibition, at one concentration (the size of the read-out at that concentration, not a potency): 14%
Beside the measured number, compound 4's estimate is 4 percentage points above it; the measured number falls inside the stated range.
By their numbers in this assay, from the lowest: compounds 1, 4, 2 and 3 (each within the scatter of the next).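

In this assay, among the compounds shown here, thiophen-3-yl in place of furan-3-yl on the saturated ring carbon gives a number 4 percentage points lower from compound 3 to compound 4 (within the scatter), the first measured step at this position. The position therefore joins the carbonyl carbon as a place where a change has not moved the read-out, though this pair of rings has the same counts of heavy atoms, donors and acceptors, so the test is a narrow one. Nothing available explains this result or bears on it.

On these data alone, whether any group at this position can move the number beyond the scatter remains open, since all four compounds carry a five-membered aromatic ring here. A phenyl ring or a pyridine ring on the saturated ring carbon, or an amine in place of the isobutyl group, would each test this further.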